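The compounds below may be only part of what the source reports. "The series", "measured", "known", "first", "only" and "open" are said of these compounds alone.

Measured so far in a functional assay on MCF7 cells (Homo sapiens) for inhibition, read by MTT assay, with a stated time of 72 h, tested at 30 uM; on this read-out higher numbers stand for more inhibition of growth at the one concentration tested and lower numbers for less inhibition of growth:
Compound 1 `C=CCc1ccc(OCc2cn(-c3ccccc3Cl)nn2)c(O)c1`: 58.3%
Compound 2 `C=CCc1ccc(OCc2cn(-c3ccc(OC)cc3)nn2)c(O)c1`: 38.8%
Compound 3 `C=CCc1ccc(OCc2cn(-c3ccc(C(=O)c4ccccc4)cc3)nn2)c(O)c1`: 40.3%

Compound 3 cannot be told apart from its closest neighbour in this small set, as the measured change shows: a number 1.5 percentage points higher from compound 2 to compound 3 (within the scatter). Compound 1 stands clear of that pair.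

The next structure, compound 4 `C=CCc1ccc(OCc2cn(-c3ccc(Br)cc3)nn2)c(O)c1`, keeps the shared core and alters one group, with bromo in place of benzoyl on an aromatic carbon.

Among the compounds with values here, no measured pair shows this exact swap, so the evidence is indirect. The closest case is a change at the same place, a number 1.5 percentage points higher from compound 2 to compound 3 (within the scatter), and it suggests that exchanging one group there need not move the number much in this assay. The other measured change is larger, a number 19.5 percentage points lower from compound 1 to compound 2 (beyond the scatter), and it shows that the group on the outer ring can matter. Within the data shown here, compound 1, with its 2-chlorophenyl group, is the only measured compound with a halogen, which hints weakly at an upward lean for a bromo compound. Together these point to a small rise that stays within the scatter. The expected change is a number 5.7 percentage points higher from compound 3 to compound 4 (within the scatter). For compound 4 the estimated value is 46%, with an expected range from 32% to 60%.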

Compound 4, percent growth inhibition at one concentration: 19.4%
Estimate against measurement, compound 4: 26.6 percentage points above; the whole stated range lies above it.
By their numbers in this assay, from the lowest: compound 4; then compounds 2 and 3 (each within the scatter of the next); then compound 1.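

On the aromatic carbon of the outer ring, the group can matter a great deal in this assay: methoxy and benzoyl gave numbers within the scatter of each other, but bromo does not join them, with a number 20.9 percentage points lower from compound 3 to compound 4 (beyond the scatter) and a number 19.4 percentage points lower from compound 2 to compound 4 (beyond the scatter) as well. A halogen on the outer ring does not by itself go with a high number, as a number 38.9 percentage points lower from compound 1 to compound 4 (beyond the scatter) shows, although this swap changes both the halogen and its place on the ring, so the two changes cannot be separated. Nothing available here explains why bromo stands apart from methoxy and benzoyl at this position.

A 4-chlorophenyl or a 2-bromophenyl group would help to separate the identity of the halogen from its place on the ring, and so to show which of the two goes with the gap between compound 1 and compound 4. On these data alone, it also remains open where an amine or a carboxylic acid on this same carbon would fall relative to bromo, methoxy and benzoyl.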